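The source may report more compounds than this note shows. Statements on the series, on what has been measured and on what is new or still open speak of the compounds shown alone.

Of the compounds shown here, three have been tested in a functional assay on SK-OV-3 cells (Homo sapiens) for inhibition, read by CCK-8 assay, with a stated time of 70 h; on this read-out higher numbers stand for weaker inhibition and lower numbers for stronger inhibition. Compound 1 `Nc1ccc(COc2ccc(OCCOCCNC3CCCC3)cc2)cc1` gives 31700 nM, compound 2 `OCCOCCOCCOc1ccc(OCc2ccccc2)cc1` gives 59400 nM, and compound 3 `c1cc2c(cc1OCCOCCNC1CCCC1)CCCC2` gives 31900 nM. Compound 1 holds the lowest of these three numbers, yet its gap to compound 3 and its gap to compound 2 both fall within the usual scatter, so the three stand level. Compound 4 `O=C(O)c1ccc(COc2ccc(OCCOCCNC3CCCC3)cc2)cc1` differs from compound 1 in one place: carboxy in place of amino on an aromatic carbon. Among the compounds with values here, no pair of measured compounds differing in a single place is available, so this kind of step has no precedent among the measured compounds. With all three measured values lying close together, compound 4 is expected to stay in the same region, with a step of a 1.1-fold higher number from compound 1 to compound 4 (0.04 log units; within the scatter) that is not expected to go beyond the scatter. Compound 4 is therefore estimated at 35000 nM, with a range from 12000 nM to 100000 nM.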

Compound 4, half-maximal inhibitory concentration: > 100000 nM
Compound 4: no number, only a limit; the forecaster's own chance of this, stated with the estimate: 10%; at least 2.8-fold (0.45 log units) between middle value and limit.
By their numbers in this assay, from the lowest: compounds 1, 3 and 2 (each within the scatter of the next). At a limit, above all of these: compound 4.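

Within the data shown here, changing 4-aminophenyl to 4-carboxyphenyl brings an at least 3.1-fold higher number from compound 1 to compound 4 (0.49 log units; beyond the scatter) in this assay, the first step in this set that lies beyond the scatter. This position is therefore not indifferent to the group it carries, which the three level earlier compounds could not show. Going by these compounds, compound 4 gives only a limit of the assay, not a number, so the full size of the step stays unknown: the limit of > 100000 nM in this assay, at which 1 of the 4 values shown sits.

The compounds shown leave open how a methyl ester, an amide or a hydroxy group would read at this place. They also leave open whether the amino group itself contributes, which a plain hydrogen there, with the rest of compound 1 kept, would show.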